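Urea aryl swap in a pyrazole series: working notes

The source may hold more compounds than are shown below. What is called first, only, known or untested is meant among the compounds shown, and "the series" means these compounds.

Two members of this series have been measured in a functional assay on OVCAR-5 cells (Homo sapiens) for inhibition, read by sulforhodamine B assay, with a stated time of 48 h, tested at 0.01 uM; a lower number here means a stronger effect, a higher number a weaker effect of the compound at the concentration tested. Compound 1 `O=C(Nc1cccc(-n2cc(-c3ccncc3)c(-c3cc(O)cc(Cl)c3)n2)c1)Nc1ccc(Cl)c(Cl)c1` gives 53% in this assay. Compound 2 `COc1cc(Cl)cc(-c2nn(-c3cccc(NC(=O)Nc4ccc(Cl)c(C(F)(F)F)c4)c3)cc2-c2ccncc2)c1` gives 54% in this assay. Compound 2 carries the highest of the two numbers, but its nearest neighbour, compound 1, sits a single point lower, a gap within the scatter, so the two read as indistinguishable. Among the compounds with values here, no pair differing in one place has been measured yet, so no step size can be taken from the data.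

Compound 3 `COc1cc(Cl)cc(-c2nn(-c3cccc(NC(=O)Nc4ccc(Cl)c(Cl)c4)c3)cc2-c2ccncc2)c1` is the next member to be tested in this assay. Relative to compound 2 it differs by chloro in place of trifluoromethyl on an aromatic carbon; cut one bond further out, the 4-chloro-3-(trifluoromethyl)phenyl end becomes 3,4-dichlorophenyl. The step from compound 2 to compound 3 is expected to be no change at the digits printed from compound 2 to compound 3 (within the scatter), that is, no change beyond the scatter, because compound 1 gives 53% while carrying the same 3,4-dichlorophenyl group. For compound 3 the estimate is 54%, with a range from 40% to 68%.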

Compound 3, a percentage reported as activity, at one concentration (the size of the read-out at that concentration, not a potency): 93%
For compound 3 the middle estimate is 39 percentage points below the measured one, and the stated range ends below it.
By their numbers in this assay, from the lowest: compounds 1 and 2 (each within the scatter of the next); then compound 3.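

With the methoxy-bearing aryl held fixed, the change from trifluoromethyl to chloro in this assay gives a number 39 percentage points higher from compound 2 to compound 3 (beyond the scatter), so this position on the urea aryl is not indifferent, and the weaker effect goes with chloro. With 3,4-dichlorophenyl held fixed, methyl in place of hydrogen on the aromatic oxygen gives a number 40 percentage points higher from compound 1 to compound 3 (beyond the scatter), so the outcome of 3,4-dichlorophenyl depends on what the other aryl carries, something the near-identical numbers of the first two compounds, which differ in two places, could not show. No evidence on hand accounts for either step.

From the compounds shown here alone, it remains open whether trifluoromethyl would hold the effect with a free hydroxy on the other aryl, and whether groups such as bromo or nitrile in place of chloro, or an amine or ethoxy in place of methoxy, would fall with compound 2 or with compound 3. These are also single-concentration read-outs in this assay, so how far the steps carry over to potency across a full concentration range stays undetermined.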